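Swapping a bromophenyl for a naphthyl on a shared core

The compounds below may be only part of what the source reports. "The series", "measured", "known", "first", "only" and "open" are said of these compounds alone.

Measured so far, in a functional assay on HCT-116 cells (Homo sapiens) for cytotoxicity, read by MTT assay, with a stated time of 48 h; a lower number here means a stronger inhibitor, a higher number a weaker inhibitor:
compound 1 `Cc1ccc(-c2cn(/N=C/c3cc4cc(C)ccc4nc3Cl)c(N)n2)cc1` gives 39600 nM
compound 2 `Cc1ccc2nc(Cl)c(/C=N/n3cc(-c4ccc(Br)cc4)nc3N)cc2c1` gives 49900 nM

Going by the values given here, compound 2 has the higher of the two numbers, but its only neighbour, compound 1, lies within the scatter: a 1.3-fold higher number from compound 1 to compound 2 (0.10 log units; within the scatter). The two compounds therefore cannot be told apart on these numbers.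

Compound 3 `Cc1ccc2nc(Cl)c(/C=N/n3cc(-c4cccc5ccccc45)nc3N)cc2c1` is not yet measured. It differs from compound 2 in one place: naphthalen-1-yl in place of 4-bromophenyl on an aromatic carbon. Among the compounds with values here, the only measured step, from compound 1 to compound 2, changed a single substituent on that same aromatic ring and stayed within the scatter. Within the data shown here, it bears on the new step only loosely, since here the whole ring is replaced by a two-ring group; no measured pair covers such a change. With nothing pointing either way, compound 3 is expected to remain close to compound 2, with the step of a 1.1-fold lower number from compound 2 to compound 3 (0.04 log units; within the scatter) expected to stay within the scatter, and a wide range to allow for the larger change. The estimate for compound 3 in this assay is 45000 nM, between 15000 nM and 135000 nM.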

Compound 3, half-maximal inhibitory concentration: 5840 nM
Compound 3: middle estimate off by 7.7-fold (0.89 log units), on the high side; the measured number lies below the stated range.
By their numbers in this assay, from the lowest: compound 3; then compounds 1 and 2 (each within the scatter of the next).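

In this assay this position proves sensitive to the group it carries: naphthalen-1-yl lowers the number whether it replaces 4-bromophenyl (an 8.5-fold lower number from compound 2 to compound 3 (0.93 log units; beyond the scatter)) or 4-methylphenyl (a 6.8-fold lower number from compound 1 to compound 3 (0.83 log units; beyond the scatter)). The earlier exchange of methyl for bromo on the single ring stayed within the scatter, so only replacing the whole ring with the two-ring group has moved the number beyond it. Nothing available here offers an explanation for this drop.

The compounds shown leave open whether a plain phenyl, a biphenyl group or a methoxy group on the naphthalene would keep the lower number. They also leave open whether the same step would hold in other cell lines or with other groups on the shared core.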